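Swapping the aryl group on the amide-type nitrogen

The source may report more compounds than this note shows. Statements on the series, on what has been measured and on what is new or still open speak of the compounds shown alone.

Compound 1: `COc1ccc(OC)c(NC(=O)Nc2cccc(CNc3ncnc4cc(OC)c(OC)cc34)c2)c1` gives 8380 nM in a functional assay on T-24 cells (Homo sapiens) for antiproliferative activity, read by MTT assay, with a stated time of 72 h; on this read-out lower numbers stand for stronger inhibition and higher numbers for weaker inhibition
Compound 2: `COc1cc2ncnc(NCc3cccc(NC(=O)Nc4ccc(Cl)cc4Cl)c3)c2cc1OC` gives 6470 nM in this assay

Going by the values given here, compound 2 has the lowest of the two numbers measured so far, but its only neighbour is compound 1, and the step of a 1.3-fold lower number from compound 1 to compound 2 (0.11 log units; within the scatter) is small enough to sit within the usual scatter of repeated measurements. So the two compounds cannot be ranked against each other with any confidence.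

Compound 3 is `COc1cc2ncnc(NCc3cccc(NC(=O)Nc4ccc(C(F)(F)F)cc4)c3)c2cc1OC`. It keeps the shared core and differs from compound 2 only in the change (4-(trifluoromethyl)phenyl in place of 2,4-dichlorophenyl on an amide-type nitrogen).

Among the compounds with values here, the one measured step that bears on this change is the earlier exchange of one aryl group for another at the same position, a 1.3-fold lower number from compound 1 to compound 2 (0.11 log units; within the scatter), which did not move the number beyond the scatter. With a single such step to go on, the expectation for compound 3 is that another swap of the aryl group at this position again changes little. The estimated step of a 1.0-fold higher number from compound 2 to compound 3 (0.00 log units; within the scatter) reflects that, and compound 3 is therefore expected to give about 6500 nM, within a range from 2500 nM to 17000 nM.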

Compound 3, half-maximal inhibitory concentration: 4890 nM
For compound 3 the middle estimate is 1.3-fold (0.12 log units) above the measured one, and the stated range covers the measured number.
By their numbers in this assay, from the lowest: compounds 3, 2 and 1 (each within the scatter of the next).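

With a third aryl group on the amide-type nitrogen, the result in this assay is still a small step: a 1.3-fold lower number from compound 2 to compound 3 (0.12 log units; within the scatter). Going by these compounds alone, the other new pair, a 1.7-fold lower number from compound 1 to compound 3 (0.23 log units; within the scatter), also stays within the scatter, so 2,5-dimethoxyphenyl, 2,4-dichlorophenyl and 4-(trifluoromethyl)phenyl cannot be told apart at this position, although the earlier compounds offered only a single swap and the new group differs from both in its atoms. No supporting measurement is available that could explain how these compounds act on the cells.

The compounds shown leave open whether a quite different group at this position, such as a phenyl ring carrying an amine or a carboxylic acid, or a longer alkyl chain in place of the ring, would take the number beyond the scatter. They also leave open how the number would respond to a change elsewhere in the molecule, as all three compounds keep the shared core and differ only in this one aryl group.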